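This account rests on a few compounds, and the source may have more. Where it says the series, first, only, none or still open, it means among the compounds named here.

In a functional assay on Raji cells (Homo sapiens) for antiproliferative activity, read by MTT assay, with a stated time of 48 h (a lower number here means a stronger inhibitor, a higher number a weaker inhibitor), compound 1 `N#Cc1nc2c(-c3nc4ccccc4[nH]3)c(N)n(CCN3CCCC3)c2nc1C#N` reads > 50000 nM, which is a limit of the assay and not a number. For the measured compounds named here, compound 2 `N#Cc1nc2c(-c3nc4ccccc4[nH]3)c(N)n(CCO)c2nc1C#N` gives 5520 nM, the only true number so far. Compound 3 `CCCCn1c(N)c(-c2nc3ccccc3[nH]2)c2nc(C#N)c(C#N)nc21` differs from compound 2 by ethyl in place of hydroxy on a saturated chain carbon, two bonds along the chain from an aromatic nitrogen. Going by the values given here, the one measured step at this place, an at least 9.0-fold lower number from compound 1 to compound 2 (0.95 log units; beyond the scatter), brought in hydroxy for pyrrolidin-1-yl and rests on (the limit of > 50000 nM in this assay, at which 1 of the 2 values shown sits). It shows that this place can matter, but it is a different exchange and sets no direction here. The estimated step in this assay is a 1.1-fold higher number from compound 2 to compound 3 (0.04 log units; within the scatter), with none beyond the scatter expected. For compound 3 the expected value is 6000 nM, within an estimated range of 1800 nM to 25000 nM.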

Compound 3, half-maximal inhibitory concentration: > 50000 nM
Compound 3 was reported as a limit; the forecaster's own chance of this, stated with the estimate: 20%; at least 8.3-fold (0.92 log units) between middle value and limit.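

In this assay, putting ethyl in place of hydroxy, which turns 2-hydroxyethyl into butyl, gives an at least 9.0-fold higher number from compound 2 to compound 3 (0.95 log units; beyond the scatter). The chain therefore matters for more than the pyrrolidin-1-yl exchange, and of the three compounds only compound 2, with its hydroxy, gives a true number. Compound 3 is a limit, so this step gives only a minimum size: the limit of > 50000 nM in this assay, at which 2 of the 3 values shown sit.

The step from compound 1 to compound 3 cannot be read, as both are limits. Still open, going by these compounds, is whether another group at the chain end, such as a carboxylic acid, a primary amine or a longer chain ending in hydroxy, would give a true number.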